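This account rests on a few compounds, and the source may have more. Where it says the series, first, only, none or still open, it means among the compounds named here.

Compound 2 `Brc1ccc(Cn2nnc3c(Br)cccc32)cc1` and compound 1 `Clc1ccc(Cn2nnc3c(Br)cccc32)cc1` share one core, and compound 3 `Brc1cc(Br)c2nnn(CC3CC3)c2c1` is built on another core; the difference between the two cores is not broken down here. In an ADME assay on microsomes from liver (Homo sapiens) for metabolic stability, tested at 2.5 uM (a higher number here means faster removal of the compound, a lower number slower removal), compound 2 gives 0.4 mL/min/g and compound 1 gives 0.6 mL/min/g, a step of a 1.5-fold higher number from compound 2 to compound 1 (0.18 log units; within the scatter) for the change (chloro in place of bromo on an aromatic carbon). In this assay compound 3 gives 0.6 mL/min/g, level with compound 1 at the digits shown. Compound 4 `Clc1cc(Br)c2nnn(CC3CC3)c2c1` carries the same kind of change on the core of compound 3, (chloro in place of bromo on an aromatic carbon), though here the place sits meta to a bromo group and to a fused ring, and para to a fused ring, rather than para to a large group. Because the earlier step of a 1.5-fold higher number from compound 2 to compound 1 (0.18 log units; within the scatter) stayed within the scatter, the step from compound 3 to compound 4 is expected to be about a 1.2-fold higher number from compound 3 to compound 4 (0.07 log units; within the scatter), so compound 4 is estimated at 0.7 mL/min/g, between 0.35 mL/min/g and 1.4 mL/min/g.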

Compound 4, intrinsic clearance in a liver preparation (reported as CLH), per the amount of preparation that the assay uses: 0.5 mL/min/g
Compound 4: middle estimate off by 1.4-fold (0.15 log units), on the high side; the range from low to high includes it.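

In this assay, chloro in place of bromo on an aromatic carbon gives a 1.2-fold lower number from compound 3 to compound 4 (0.08 log units; within the scatter), and this can be set beside the same change on the other core: the same change on two cores in this assay, a 1.5-fold higher number (0.18 log units; within the scatter) from compound 2 to compound 1 and a 1.2-fold lower number (0.08 log units; within the scatter) from compound 3 to compound 4, 1.8-fold (0.26 log units) apart, within the scatter of two such steps. In these two pairs, the change therefore carries from one core to the other with no difference that stands clear of the scatter, and neither step stands clear of it alone. This does not show that the two steps are identical, or that the change would behave alike on a further core or at another place; only two pairs are shown. The compounds shown leave open what happens when the halogen gives way to a different group, such as an amine or a carboxylic acid. They also leave open what a longer chain would do on either core.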